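Cytotoxicity notes on compound 1 and compound 3

This account rests on a few compounds, and the source may have more. Where it says the series, first, only, none or still open, it means among the compounds named here.

Compound 1 `O=C(OC[C@H]1O[C@@H](O[C@@H](C(=O)O)c2ccccc2)[C@H](O)[C@@H](O)[C@@H]1O)c1ccccc1` was tested in an ADME assay on A549 cells (Homo sapiens) for cytotoxicity; on this read-out lower numbers stand for stronger inhibition and higher numbers for weaker inhibition. In this assay compound 1 gives only a limit, > 10000 nM. Compound 2 `O=C(OC[C@H]1O[C@@H](OC[C@H]2O[C@@H](OC(=O)c3ccccc3)[C@H](O)[C@@H](O)[C@@H]2O)[C@H](O)[C@@H](O)[C@@H]1O)c1ccccc1` likewise gives only a limit in this assay, > 10000 nM. For the measured compounds named here, the two results share (the limit of > 10000 nM in this assay, at which 2 of the 2 values shown sit), so no measured step between compounds exists. Compound 3 `COc1cc(CO)ccc1O[C@@H]1O[C@H](COC(=O)c2ccccc2)[C@@H](O)[C@H](O)[C@H]1O` differs from compound 1 by 4-(hydroxymethyl)-2-methoxyphenyl in place of carboxy(phenyl)methyl on an oxygen on a saturated carbon. In this assay no shift beyond the scatter is expected: a step that the limit leaves unreadable from compound 1 to compound 3. Compound 3 is expected to give about 15000 nM in this assay, between 7000 nM and 40000 nM, most probably again reported only as a limit.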

Compound 3, half-maximal inhibitory concentration: > 10000 nM
Compound 3: no number, only a limit; the forecaster's own chance of this, stated with the estimate: 85%; the middle value does not contradict the limit.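

Compound 1 and compound 3 both give only a limit in this assay and no step can be read between them: the limit of > 10000 nM in this assay, at which 3 of the 3 values shown sit.

The compounds shown leave open whether 4-(hydroxymethyl)-2-methoxyphenyl in place of carboxy(phenyl)methyl shifts this read-out at all.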